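Methoxy to Ethoxy Oxime Ether: Expected Cytotoxicity of Compound 4

The compounds below may be only part of what the source reports. "The series", "measured", "known", "first", "only" and "open" are said of these compounds alone.

Compound 3 `CON=C1CCC(CN2CCN(c3nc(=O)c4cc(C(F)(F)F)cc([N+](=O)[O-])c4s3)[C@@H](C)C2)CC1` carries a methoxy oxime ether on its cyclohexane ring and a methyl on the piperazine. In an ADME assay on Vero cells (Chlorocebus sabaeus) for cytotoxicity (on this read-out lower numbers stand for higher toxicity in this test and higher numbers for lower toxicity in this test), compound 3 gives > 64 ug/mL, which is a limit of the test and not a number. Two related compounds have been measured alongside it. In this assay compound 1 `CCON=C1CCC(CN2CCN(c3nc(=O)c4cc(C(F)(F)F)cc([N+](=O)[O-])c4s3)CC2)CC1` gives > 64 ug/mL, again a limit. In this assay compound 2 `CCON=C1CCC(CN2CCN(c3nc(=O)c4cc(C(F)(F)F)cc([N+](=O)[O-])c4s3)[C@H](C)C2)CC1` gives > 64 ug/mL, also a limit. Among the measured compounds shown here, the one single-point step among them, a step that the two limits leave unreadable from compound 1 to compound 2, adds a methyl on a saturated ring carbon, and its size cannot be read because both ends are limits. For the measured compounds named here, the only evidence on this set is therefore (the limit of > 64 ug/mL in this assay, at which 3 of the 3 values shown sit), so no compound can be called more or less toxic than another.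

Compound 4 `CCON=C1CCC(CN2CCN(c3nc(=O)c4cc(C(F)(F)F)cc([N+](=O)[O-])c4s3)[C@@H](C)C2)CC1` differs from compound 3 in one place: methyl in place of hydrogen on a saturated chain carbon bound to an oxygen on an unsaturated carbon. Because of the limit of > 64 ug/mL in this assay, at which 3 of the 3 values shown sit, with every measured compound sitting at the same limit, the step that the limit leaves unreadable from compound 3 to compound 4 is expected to be none beyond the scatter, and compound 4 is expected to reach 80 ug/mL, most likely again reported as a limit, within 50 ug/mL to 150 ug/mL.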

Compound 4, half-maximal cytotoxic concentration: > 64 ug/mL
Compound 4 gave a limit, no number; the forecaster's own chance of this, stated with the estimate: 90%; the middle value lies beyond the limit too.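

In this assay compound 4 gives > 64 ug/mL, a limit and not a number, so none of the steps from compound 1, compound 2 or compound 3 to compound 4 can be read: the limit of > 64 ug/mL in this assay, at which 4 of the 4 values shown sit.

The compounds shown leave open where the true cytotoxic concentration of each lies, and whether the change from methoxy to ethoxy alters it at all.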